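Benzyl in place of 4-ethylphenyl on the shared core

This account rests on a few compounds, and the source may have more. Where it says the series, first, only, none or still open, it means among the compounds named here.

Compound 1 `Nc1cccc(-c2cn3nc(-c4cccs4)sc3n2)c1`, compound 2 `C=C(Br)C(=O)Nc1cccc(-c2cn3nc(-c4ccc(CC)cc4)sc3n2)c1` and compound 3 `C=C(Br)C(=O)Nc1cccc(-c2cn3nc(-c4ccc(F)cc4)sc3n2)c1` share one core. In a functional assay on CCRF-CEM cells (Homo sapiens) for inhibition, read by cell counting, with a stated time of 3 days (on this read-out higher numbers stand for weaker inhibition and lower numbers for stronger inhibition), compound 1 gives only a limit of the assay, > 250000 nM. Compound 2 gives 3400 nM, the highest of the two numbers recorded. Within the data shown here, compound 3 gives 830 nM, and the one measured step between numbers is a 4.1-fold lower number from compound 2 to compound 3 (0.61 log units; beyond the scatter). Compound 4 `C=C(Br)C(=O)Nc1cccc(-c2cn3nc(Cc4ccccc4)sc3n2)c1` differs from compound 2 in that (benzyl in place of 4-ethylphenyl on an aromatic carbon). Among the measured compounds shown here, that change is of another kind than the fluoro-for-ethyl step, which therefore bears on it only loosely, and no measured step speaks directly to it. Compound 2 is expected to change by a 1.5-fold higher number from compound 2 to compound 4 (0.17 log units; within the scatter), a step of uncertain direction that may not clear the scatter. Compound 4 is therefore estimated at 5000 nM, within 1200 nM to 20000 nM.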

Compound 4, half-maximal inhibitory concentration: 4200 nM
The estimate for compound 4 lay 1.2-fold (0.08 log units) above the measured number; the measured number falls inside the stated range.
By their numbers in this assay, from the lowest: compound 3; then compounds 2 and 4 (each within the scatter of the next). At a limit, above all of these: compound 1.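

In this assay, benzyl in place of 4-ethylphenyl on this aromatic carbon gives a 1.2-fold higher number from compound 2 to compound 4 (0.09 log units; within the scatter), so these two groups cannot be told apart here. Benzyl in place of 4-fluorophenyl gives a 5.1-fold higher number from compound 3 to compound 4 (0.70 log units; beyond the scatter), which leaves compound 3 as the only one of the three bromoacrylamides set apart by this position. Nothing shown here accounts for either step.

On these data alone, whether an amine or a carboxylic acid in place of the fluoro group would hold or lose this number stays open, as does the effect of a longer chain in place of benzyl.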